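A few compounds are considered here, and "the series" means these few. Any claim that something is new, unique, unknown or untested is made for them only; others in the source may bear on it.

Measured in a physicochemical assay for metabolic stability, read by HPLC; a higher number here means that the compound lasts longer, a lower number that the compound disappears faster:
- Compound 1 `Cc1cn([C@H]2C[C@H](N=[N+]=[N-])[C@@H](COP(=O)(O)Oc3ccc(Br)cc3)O2)c(=O)[nH]c1=O`: 7.97 h
- Compound 2 `Cc1ncccc1OP(=O)(O)OC[C@H]1O[C@@H](n2cc(C)c(=O)[nH]c2=O)C[C@@H]1N=[N+]=[N-]`: 15.8 h

Only these two numbers exist so far. Compound 2 at 15.8 h and compound 1 at 7.97 h lie within the scatter of each other, so neither stands clear of the other.

Compound 3 `Cc1cn([C@H]2C[C@H](N=[N+]=[N-])[C@@H](COP(=O)(O)Oc3ccc(Cl)cc3Cl)O2)c(=O)[nH]c1=O` has not yet been measured. It differs from compound 2 in one place: 2,4-dichlorophenyl in place of 2-methylpyridin-3-yl on an oxygen. In words, 2,4-dichlorophenyl comes in place of 2-methylpyridin-3-yl on an oxygen. This brings back an aromatic ring of carbon only, as in the 4-bromophenyl of compound 1.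

Among the compounds with values here, one measured step bears on this change, and it shows a 2.0-fold higher number from compound 1 to compound 2 (0.30 log units; within the scatter). A step of similar size in the opposite direction is therefore expected in this assay, hardly beyond the scatter. The expected step is a 2.3-fold lower number from compound 2 to compound 3 (0.35 log units; beyond the scatter). Compound 3 is estimated at 7 h, with an expected range from 3 h to 16 h.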

Compound 3, half-life: 3.03 h
Beside the measured number, compound 3's estimate is 2.3-fold (0.36 log units) above it; measured number inside the range.
By their numbers in this assay, from the lowest: compound 3; then compounds 1 and 2 (each within the scatter of the next).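

In this assay the group on the oxygen bound to phosphorus now gives a change that stands clear of the scatter: 2,4-dichlorophenyl brings a 5.2-fold lower number from compound 2 to compound 3 (0.72 log units; beyond the scatter) and also a 2.6-fold lower number from compound 1 to compound 3 (0.42 log units; beyond the scatter). Compound 3 therefore separates from both earlier compounds, while compound 1 and compound 2 remain within the scatter of each other. Having an aromatic ring of carbon only does not by itself settle the half-life, since compound 1 and compound 3 both carry such a ring, and the data give no reason for the difference.

The compounds shown leave open whether the lower number goes with the two chlorines together or with one of them alone. They also leave open how a plain phenyl, a 4-chlorophenyl or an open alkyl chain on that oxygen would compare.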